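Methyl for fluoro on the amide-bound aryl of compound 2

The source may report more compounds than this note shows. Statements on the series, on what has been measured and on what is new or still open speak of the compounds shown alone.

Within the data shown here, compound 2 `Cc1c(C(=O)Nc2ccccc2)sc(N)c1C(=O)Nc1ccc(F)c(F)c1` gives 40000 nM in an ADME assay on HepG2 cells (Homo sapiens) for cytotoxicity, read by XTT assay, with a stated time of 2 days (a higher number here means that more compound is tolerated, a lower number that less compound is tolerated), the only full number in the set. Compound 1 `Cc1c(C(=O)Nc2ccccc2)sc(N)c1C(=O)Nc1ccccc1` sits at the limit > 100000 nM, a limit of this assay rather than a number (the limit of > 100000 nM in this assay, at which 1 of the 2 values shown sits). Among the measured compounds shown here, the one measured step, an at least 2.5-fold lower number from compound 1 to compound 2 (0.39 log units; beyond the scatter), is the only guide. Compound 3 `Cc1cc(NC(=O)c2c(N)sc(C(=O)Nc3ccccc3)c2C)ccc1F` differs from compound 2 by methyl in place of fluoro on an aromatic carbon. That change is not the one that was measured: the step from compound 1 to compound 2 added two fluoro groups, whereas the step to compound 3 swaps one of them for methyl and keeps the 4-fluoro. For the measured compounds named here, no step of this kind is available, so no clear direction is expected; the estimated step of a 1.3-fold higher number from compound 2 to compound 3 (0.10 log units; within the scatter) is expected to stay within the scatter, with a real chance that compound 3 reaches the limit. Compound 3 is expected to give 50000 nM, between 20000 nM and 130000 nM.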

Compound 3, half-maximal cytotoxic concentration: 40000 nM
For compound 3 the middle estimate is 1.3-fold (0.10 log units) above the measured one; low and high end bracket the measured number.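

In this assay, this position on the amide-bound aryl does not separate methyl from fluoro, as the swap gives no change at the digits printed from compound 2 to compound 3 (within the scatter). Measured against the phenyl of compound 1, the 4-fluoro-3-methylphenyl group gives an at least 2.5-fold lower number from compound 1 to compound 3 (0.39 log units; beyond the scatter), so the lower number seen with the 3,4-difluorophenyl group of compound 2 does not require a second fluoro group. Compound 1 stands at a limit, so the full size of both steps from it remains unknown: the limit of > 100000 nM in this assay, at which 1 of the 3 values shown sits.

The compounds shown leave open whether the 4-fluoro group alone gives the same number as the two disubstituted aryl groups. Also open, on these data alone, is how the number responds at this position to a group of another kind, such as an amine, a carboxylic acid or a methoxy group.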